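The source may hold more compounds than are shown below. What is called first, only, known or untested is meant among the compounds shown, and "the series" means these compounds.

Compound 2, `CC(=O)OCCOn1cnc2c(S)nc(N)nc21`, is the starting point of this step. In a functional assay (Homo sapiens) for inhibition (a lower number here means a stronger inhibitor, a higher number a weaker inhibitor), compound 2 gives only a limit, > 500000 nM. Among the compounds with values here, its one measured relative is compound 1, `CC(=O)OCCOn1cnc2c(Cl)nc(N)nc21`, which differs from it in a single place. In this assay compound 1 likewise gives only a limit, > 500000 nM. The step that the two limits leave unreadable from compound 1 to compound 2 therefore cannot be sized, because the limit of > 500000 nM in this assay, at which 2 of the 2 values shown sit, holds both values. The unmeasured compound is compound 3, `CC(=O)OCCOn1cnc2c(S)nc(F)nc21`; it differs from compound 2 as follows: fluoro in place of amino on an aromatic carbon. Within the data shown here, no measured step involves an amino group or a fluoro group, so there is no guide beyond the two limits already described. The step of a number no higher from compound 2 to compound 3 (the limit leaves the size open) is thus expected to be of unknown size, with the most likely outcome that the assay again reports only a limit. Compound 3 is estimated at 500000 nM, within a range of 100000 nM to 2000000 nM.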

Compound 3, half-maximal inhibitory concentration: > 500000 nM
Compound 3 ended at the assay's limit (the forecaster's own chance of this, stated with the estimate: 85%); the middle value sits exactly at the limit.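

No size can be read for the swap of amino for fluoro between compound 2 and compound 3, because both results are limits rather than numbers: the limit of > 500000 nM in this assay, at which 3 of the 3 values shown sit. The compounds shown leave open whether any change to the shared core gives a measurable value in this assay.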